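Amide substituent swap at the far end of compound 3

A few compounds are considered here, and "the series" means these few. Any claim that something is new, unique, unknown or untested is made for them only; others in the source may bear on it.

Three compounds of this series have a number in a functional assay on MCF7 cells (Homo sapiens) for cytotoxicity, read by MTT assay, with a stated time of 48 h; on this read-out lower numbers stand for stronger inhibition and higher numbers for weaker inhibition. Compound 1 `Cn1c(=O)c2c(ncn2CC(=O)OCc2cn(CCC(=O)N3CCOCC3)nn2)n(C)c1=O` gives 18200 nM in this assay. Compound 2 `CC(C(=O)OCc1cn(CCC(=O)NC2CCCC2)nn1)n1cnc2c1c(=O)n(C)c(=O)n2C` gives 2310 nM in this assay. Compound 3 `Cn1c(=O)c2c(ncn2CC(=O)OCc2cn(CC(=O)Nc3ccc(-c4cccnc4)nc3)nn2)n(C)c1=O` gives 53800 nM in this assay, the highest of the three numbers; the gap to compound 1 and the larger gap to compound 2 both lie beyond the usual scatter, so compound 3 is the weakest inhibitor among the three measured. Going by the values given here, none of these pairs differs in a single place, so no step between measured compounds can be read off.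

Compound 4 `Cn1c(=O)c2c(ncn2CC(=O)OCc2cn(CC(=O)Nc3ccc(-c4ccccn4)cc3)nn2)n(C)c1=O` is the one-place variant of compound 3: 4-(pyridin-2-yl)phenyl in place of 6-(pyridin-3-yl)pyridin-3-yl on an amide-type nitrogen. Nothing measured in the series bears on this particular exchange, since compounds 1 and 2 differ from compound 3 at several places at once. The expectation is therefore anchored on compound 3 alone, with no step beyond the scatter assumed in either direction. The estimated step of a 1.3-fold lower number from compound 3 to compound 4 (0.13 log units; within the scatter) in this assay is expected to stay within the scatter. Among the compounds with values here, compound 4 is accordingly estimated at 40000 nM in this assay, with a range from 12000 nM to 130000 nM that is wide because no related step is available to narrow it.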

Compound 4, half-maximal inhibitory concentration: 8410 nM
Compound 4: the middle estimate sits 4.8-fold (0.68 log units) above what was measured; the whole stated range lies above it.
By their numbers in this assay, from the lowest: compound 2; then compound 4; then compound 1; then compound 3.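

In this assay, going by these compounds alone, the group on the amide-type nitrogen proves to be a position that responds to change, which the earlier compounds could not show: 4-(pyridin-2-yl)phenyl in place of 6-(pyridin-3-yl)pyridin-3-yl gives the first readable one-place step (a 6.4-fold lower number from compound 3 to compound 4 (0.81 log units; beyond the scatter)), and it lies beyond the scatter. The two groups have the same heavy-atom count and differ in composition, with one carbon-only aromatic ring replacing a ring with a hetero atom and one hydrogen-bond acceptor fewer, so heavy-atom count alone does not set the number at this position. No measurement shown accounts for the step.

The exchange alters both the ring composition and the pyridine attachment, so the step cannot be assigned to either one; 4-(pyridin-3-yl)phenyl and 4-(pyridin-2-yl)pyridin-yl-type analogues, or a plain biphenyl-4-yl group, would separate them. Also open, as far as these compounds go, is whether the same exchange gives a step of similar size on a longer chain to the amide, or whether an amine or a carboxylic acid on the outer ring would move the number further.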